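The compounds below may be only part of what the source reports. "The series", "measured", "known", "first", "only" and "open" are said of these compounds alone.

Measured in a functional assay on MKN-45 cells (Homo sapiens) for cytotoxicity, read by MTT assay, with a stated time of 72 h; on this read-out higher numbers stand for weaker inhibition and lower numbers for stronger inhibition:
compound 1 `COc1cc2c(Oc3ccc(NC(=O)c4nnn(-c5ccc(C)cc5)c4C(F)(F)F)cc3F)ccnc2cc1OCCCN1CCCC1` gives 210 nM;
compound 2 `COc1cc2c(Oc3ccc(NC(=O)c4nnn(-c5ccc(C)cc5)c4C(F)(F)F)cc3F)ccnc2cc1OCCCN1CCC(C)CC1` gives 140 nM.

Compound 2 has the lower of these two numbers, but the step between them is a 1.5-fold lower number from compound 1 to compound 2 (0.18 log units; within the scatter), so on this read-out the two compounds cannot be told apart. Compound 3 `COc1cc2c(Oc3ccc(NC(=O)c4nnn(-c5cccc(Br)c5)c4C(F)(F)F)cc3F)ccnc2cc1OCCCN1CCC(C)CC1` has not yet been measured in this assay. It differs from compound 2 at a single place: 3-bromophenyl in place of 4-methylphenyl on an aromatic nitrogen. Among the compounds with values here, the one measured step concerns a different part of the shared core, the group on the chain, and was a 1.5-fold lower number from compound 1 to compound 2 (0.18 log units; within the scatter); nothing measured so far touches the aromatic nitrogen that carries the phenyl ring, so the data give no guide to how a change there moves the number. The expected step is therefore a 1.1-fold higher number from compound 2 to compound 3 (0.03 log units; within the scatter), no larger than the scatter. In this assay compound 3 is expected to give 150 nM, with a range from 50 nM to 500 nM.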

Compound 3, half-maximal inhibitory concentration: 120 nM
Beside the measured number, compound 3's estimate is 1.3-fold (0.10 log units) above it, within the range that was stated.
By their numbers in this assay, from the lowest: compounds 3, 2 and 1 (each within the scatter of the next).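

Within the data shown here, compound 3 gives the first reading at the aromatic nitrogen of the five-membered ring: replacing 4-methylphenyl with 3-bromophenyl gives a 1.2-fold lower number from compound 2 to compound 3 (0.07 log units; within the scatter) in this assay. Compound 2 and compound 3 therefore cannot be told apart, even though the new group brings in bromine and carries its substituent at a different numbered place on the phenyl ring. Nothing available explains this result.

This single swap changes both the substituent and its place on the phenyl ring, so 3-methylphenyl or 4-bromophenyl would be needed to separate those two changes. From the compounds shown here alone, how this position would respond to plain phenyl, to a phenyl ring bearing an amine or a carboxylic acid, or to an ethyl group in place of the ring remains open.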